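Swapping acetyl for dimethylamino on a pyrazole pair

This account rests on a few compounds, and the source may have more. Where it says the series, first, only, none or still open, it means among the compounds named here.

The account concerns two measured compounds and one that awaits measurement. Compound 1 `COc1cc(C)cc(-c2c(-c3ccnc(-c4ccc(C(C)=O)cc4)c3)cnn2CC#N)c1` was tested in a functional assay on MDA-MB-231 cells (Homo sapiens) for cytotoxicity, read by sulforhodamine B assay, with a stated time of 48 h, tested at 0.01 uM (a higher number here means a weaker effect of the compound at the concentration tested, a lower number a stronger effect), and gave 95%. Compound 2 `Cc1cc(O)cc(-c2nn(CC#N)cc2-c2ccnc(-c3ccc(N(C)C)cc3)c2)c1` gave 98% in the same setting. Compound 1 thus holds the lower of the two numbers, yet the two values differ by an amount that lies within the scatter, so neither compound can be called the stronger.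

Compound 3 `COc1cc(C)cc(-c2c(-c3ccnc(-c4ccc(N(C)C)cc4)c3)cnn2CC#N)c1` differs from compound 1 in one place: dimethylamino in place of acetyl on an aromatic carbon. The group sits on an aromatic carbon of a six-membered aromatic ring of carbon only, para to a large group. Among the compounds with values here, no measured pair that differs by exactly this change is available. Since compound 2, which carries the dimethylamino group, gave 98% and compound 1 gave 95%, the expected step of a number 1 percentage points higher from compound 1 to compound 3 (within the scatter) is none beyond the scatter. Compound 3 is therefore estimated at 96%, within a range from 87% to 104%.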

Compound 3, a percentage reported as activity, at one concentration (the size of the read-out at that concentration, not a potency): 88%
Compound 3: the middle estimate sits 8 percentage points above what was measured; the range from low to high includes it.
By their numbers in this assay, from the lowest: compounds 3, 1 and 2 (each within the scatter of the next).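

Within the data shown here, the pair of compound 1 and compound 3 gives the first direct reading of this change at this place, on an aromatic carbon of the six-membered carbon ring, para to a large group. In this assay, dimethylamino in place of acetyl gives a number 7 percentage points lower from compound 1 to compound 3 (within the scatter) and so does not separate the two compounds, although the two groups differ in their heavy atoms, with nitrogen entering and oxygen and the double bond leaving. Nothing measured here offers an explanation of this result.

One pair at a single concentration says little about this place in general. Going by these compounds, whether a carboxylic acid or a longer amine chain on the same carbon would give a step beyond the scatter remains open.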